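Adding a tetrazolyl group to compound 2

The compounds below may be only part of what the source reports. "The series", "measured", "known", "first", "only" and "open" are said of these compounds alone.

For the measured compounds named here, compound 2 `O=C(Nc1ccccc1)c1ccc(-c2nn[nH]n2)cc1` has the higher of the two numbers so far in a functional assay on the whole organism (stomach) with Rattus norvegicus as the target (a higher number here means that more compound is needed for the effect, a lower number that less compound is needed), at 40 mg/kg, while compound 1 `O=C(O)c1ccc(NC(=O)c2ccc(-c3nn[nH]n3)cc2)cc1` gives 3.5 mg/kg. Compound 3 `O=C(Nc1ccccc1-c1nn[nH]n1)c1ccc(-c2nn[nH]n2)cc1` carries 2H-tetrazol-5-yl in place of hydrogen on an aromatic carbon, ortho to a large group: 2H-tetrazol-5-yl in place of hydrogen on an aromatic carbon. Going by the values given here, the only measured step bearing on this is an 11-fold higher number from compound 1 to compound 2 (1.06 log units; beyond the scatter), large and beyond the scatter, where hydrogen replaces carboxy. That step concerns another group, so only part of its size is expected to carry over, in the opposite direction. The expected step is a 4.0-fold lower number from compound 2 to compound 3 (0.60 log units; beyond the scatter). Compound 3 is estimated at 10 mg/kg, with a range of 2 mg/kg to 45 mg/kg.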

Compound 3, dose for 50% inhibition: 6.1 mg/kg
Beside the measured number, compound 3's estimate is 1.6-fold (0.21 log units) above it; measured number inside the range.
By their numbers in this assay, from the lowest: compounds 1 and 3 (each within the scatter of the next); then compound 2.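

In this assay, 2H-tetrazol-5-yl in place of hydrogen on an aromatic carbon, ortho to a large group, gives a 6.6-fold lower number from compound 2 to compound 3 (0.82 log units; beyond the scatter) and so shows that this position accepts a substituent and that the number falls with it. For the compounds shown here, the only earlier step on this ring concerned carboxy, so this is the first reading for a group at this place. No measurement on hand accounts for the drop.

Going by these compounds, whether a carboxylic acid or an amine at this same position would lower the number as far remains open. Also open, on these data alone, is whether 2H-tetrazol-5-yl on another carbon of this ring would do the same.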